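The source may report more compounds than this note shows. Statements on the series, on what has been measured and on what is new or still open speak of the compounds shown alone.

The measured compounds:
compound 1, `CS(=O)(=O)c1ccc(-c2cnc3[nH]cc(-c4nnc(-c5ccncc5)o4)c(=O)c3c2)cc1`, gives 4.27%
compound 2, `CS(=O)(=O)c1ccc(-c2cnc3[nH]cc(-c4nnc(-c5ccc(F)cc5)o4)c(=O)c3c2)cc1`, gives 8.1%
compound 3, `CS(=O)(=O)c1ccc(-c2cnc3[nH]cc(-c4nnc(-c5ccccc5)o4)c(=O)c3c2)cc1`, gives 2.83%

All three share one core and were tested in a functional assay on MCF7 cells (Homo sapiens) for inhibition, read by MTT assay, with a stated time of 24 h, tested at 10 uM; on this read-out lower numbers stand for less inhibition of growth and higher numbers for more inhibition of growth at the one concentration tested. They differ only in the aromatic ring that hangs off the oxadiazole: a pyridin-4-yl in compound 1, a 4-fluorophenyl in compound 2, a plain phenyl in compound 3. Compound 3 gives the lowest of the three numbers, but both gaps to it are small: a number 1.4 percentage points lower from compound 1 to compound 3 (within the scatter), and a number 5.3 percentage points lower from compound 2 to compound 3 (within the scatter). In other words, none of the three rings sets itself apart.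

Compound 4, `CS(=O)(=O)c1ccc(-c2cnc3[nH]cc(-c4nnc(-c5ccc(Cl)cc5)o4)c(=O)c3c2)cc1`, is the next member. It differs from compound 3 by chloro in place of hydrogen on an aromatic carbon; cut one bond further out, the change reads phenyl to 4-chlorophenyl. For the measured compounds named here, the step that touches the same spot is the one between compound 2 and compound 3, where fluoro gave way to hydrogen, and it stayed within the scatter. The remaining step, a number 3.8 percentage points higher from compound 1 to compound 2 (within the scatter), also stayed within the scatter. On this showing a single halogen at that position is expected to move the read-out little, so compound 4 is expected to give a step of a number 3.2 percentage points higher from compound 3 to compound 4 (within the scatter), not beyond the scatter. The estimate for compound 4 is therefore 6%, within a range from 0% to 15%.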

Compound 4, percent growth inhibition at one concentration: 13.1%
For compound 4 the middle estimate is 7.1 percentage points below the measured one; low and high end bracket the measured number.
By their numbers in this assay, from the lowest: compounds 3, 1, 2 and 4 (each within the scatter of the next, the first and the last beyond it).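

In this assay, for the compounds shown here, chloro in place of hydrogen on the six-membered aromatic ring, para to a large group, gives the only step in this short series that passes the usual scatter (a number 10.3 percentage points higher from compound 3 to compound 4 (beyond the scatter)), and that step is modest. This shows that the ring position is not entirely silent, although the earlier swaps among the three rings gave no sign of it. The separation is limited, however: the other two new steps (a number 5 percentage points higher from compound 2 to compound 4 (within the scatter)) and (a number 8.8 percentage points higher from compound 1 to compound 4 (within the scatter)) stay within the scatter, so 4-chlorophenyl stands apart only from plain phenyl, and nothing in the data explains even that gap.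

The compounds shown leave open whether bromo, methyl, methoxy or an amine on the same ring carbon would carry the number further, and whether chloro would do the same elsewhere on that ring. With only one concentration tested, they also leave open how compound 4 would behave at higher or lower concentrations.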